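Replacing an Aminomethyl Group with Methoxycarbonyl: Cytotoxicity Outlook

The source may report more compounds than this note shows. Statements on the series, on what has been measured and on what is new or still open speak of the compounds shown alone.

Of the compounds shown here, two sharing one core have been tested in an ADME assay on HEp-2 cells (Homo sapiens) for cytotoxicity; on this read-out lower numbers stand for higher toxicity in this test and higher numbers for lower toxicity in this test. Compound 1 `CC(C)CCn1c(Cn2c(=O)n(C(C)C)c3ccccc32)nc2c(CN)cccc21` gives 7000 nM in this assay, the higher of the two numbers. Compound 2 `CC(C)CCn1c(Cn2c(=O)n(C(C)C)c3ccccc32)nc2cc(C(C)(C)N)ccc21` gives 3270 nM in this assay, and the gap between compound 2 and compound 1 lies beyond the usual scatter, so compound 1 is the less toxic of the pair.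

Compound 3 `COC(=O)c1cccc2c1nc(Cn1c(=O)n(C(C)C)c3ccccc31)n2CCC(C)C` has not yet been measured. It differs from compound 1 in one place: methoxycarbonyl in place of aminomethyl on an aromatic carbon. Going by the values given here, no measured pair shows a change of this kind, so no step in this assay can be read from the data for it.

Compound 3 is expected to give 8000 nM in this assay, with a range from 3000 nM to 25000 nM. The step of a 1.1-fold higher number from compound 1 to compound 3 (0.06 log units; within the scatter) that this estimate means is expected to stay within the usual scatter, in no clear direction.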

Compound 3, half-maximal cytotoxic concentration: 49200 nM
Beside the measured number, compound 3's estimate is 6.2-fold (0.79 log units) below it; the measured number lies above the stated range.
By their numbers in this assay, from the lowest: compound 2; then compound 1; then compound 3.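

Placing methoxycarbonyl instead of aminomethyl on this aromatic carbon, ortho to a fused ring and meta to a fused ring, clearly shifts the read-out in this assay (a 7.0-fold higher number from compound 1 to compound 3 (0.85 log units; beyond the scatter)), so the number at this position depends on the group it carries. The change takes away a hydrogen-bond donor and adds a carbonyl, but this single step cannot show which of these differences, if either, matters. No available evidence bears on why the number rises.

On these data alone, it remains open whether a carboxylic acid, a primary amide or a simple methyl group on this carbon would give a number closer to that of compound 1 or to that of compound 3. As far as these compounds go, it is equally open whether methoxycarbonyl would give a similar step on another aromatic carbon of the shared core.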